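This account rests on a few compounds, and the source may have more. Where it says the series, first, only, none or still open, it means among the compounds named here.

Compound 1 `CC(C)(C)Cc1cnc(CCc2ccc(-c3ccccc3C(=O)O)cc2)[nH]1` carries a tert-butyl on a saturated chain carbon bound to an aromatic carbon of the shared core. In an in vitro functional assay on cells for agonist activity at Bombesin receptor subtype-3 (Homo sapiens), read by luminescence and calcium flux (on this read-out higher numbers stand for an effect only at larger amounts of compound and lower numbers for an effect already at smaller amounts), compound 1 gives 106 nM, the lowest of the two numbers in hand. Compound 2 `CCCCc1cnc(CCCc2ccc(-c3ccccc3C(=O)O)cc2)[nH]1` differs from compound 1 in both its alkyl group and the length of the chain to the core. In this assay compound 2 gives 5600 nM, a value beyond the scatter from that of compound 1. Compound 3 `CCCCc1cnc(Cc2ccc(-c3ccccc3C(=O)O)cc2)[nH]1` sits at the limit of > 10000 nM in this assay, at which 1 of the 3 values shown sits, and its value, > 10000 nM, is a limit rather than a number. Compounds 2 and 3 each differ from compound 1 in more than one place. No single step can be read from them.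

Compound 4 `CCC(C)(CC)Cc1cnc(CCc2ccc(-c3ccccc3C(=O)O)cc2)[nH]1` is the compound still to be measured. It differs from compound 1 in one place: 1-ethyl-1-methylpropyl in place of tert-butyl on a saturated chain carbon bound to an aromatic carbon. Among the compounds with values here, no measured pair isolates this kind of change, so the expectation rests on compound 1 alone. One expects the step of a 1.1-fold higher number from compound 1 to compound 4 (0.05 log units; within the scatter) to remain within the scatter, with no clear direction. Compound 4 is therefore estimated at 120 nM in this assay, with a range from 35 nM to 450 nM.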

Compound 4, half-maximal effective concentration: 76 nM
The estimate for compound 4 lay 1.6-fold (0.20 log units) above the measured number, within the range that was stated.
By their numbers in this assay, from the lowest: compounds 4 and 1 (each within the scatter of the next); then compound 2. At a limit, above all of these: compound 3.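

Within the data shown here, this is the first step that changes a single place, and it gives a direct reading of the group on the saturated chain carbon bound to an aromatic carbon. In this assay, putting 1-ethyl-1-methylpropyl, with 6 heavy atoms, in place of tert-butyl, with 4, gives a 1.4-fold lower number from compound 1 to compound 4 (0.14 log units; within the scatter), so this read-out does not separate the two groups, and the position accepts the larger branched alkyl group with no change beyond the scatter. Nothing in the measurements shown gives a cause for this result.

The compounds shown leave open whether a group of another kind at this place, such as a cyclohexyl ring, an amine or a carboxylic acid, would keep a number in this range, since both groups compared here are branched, purely carbon alkyl groups. Compounds 2 and 3 differ from compound 1 in more than one place, so the effect of the length of the chain to the core, taken alone, also remains unread.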